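From phenyl to 4-fluorophenyl on compound 3

The compounds below may be only part of what the source reports. "The series", "measured", "known", "first", "only" and "open" are said of these compounds alone.

In a functional assay on DU-145 cells (Homo sapiens) for cytotoxicity, read by trypan blue exclusion, with a stated time of 96 h (a lower number here means a stronger inhibitor, a higher number a weaker inhibitor), compound 1 `COc1cc(OC)c(/C=C/S(=O)(=O)Cc2ccc(OC)c(N)c2)c(OC)c1` gives 4 nM. Compound 2 `COC(=O)CCNc1cc(CS(=O)(=O)/C=C/c2c(OC)cc(OC)cc2OC)ccc1OC` gives 1500 nM, and compound 3 `COc1cc(OC)c(/C=C/S(=O)(=O)Cc2ccc(OC)c(NC(C(=O)O)c3ccccc3)c2)c(OC)c1` gives 20 nM, which places compound 3 in the middle of the three numbers.

Compound 4 `COc1cc(OC)c(/C=C/S(=O)(=O)Cc2ccc(OC)c(NC(C(=O)O)c3ccc(F)cc3)c2)c(OC)c1` has fluoro in place of hydrogen on an aromatic carbon, so carboxy(phenyl)methyl becomes carboxy(4-fluorophenyl)methyl (fluoro in place of hydrogen on an aromatic carbon). Among the compounds with values here, none of the measured steps tests a fluoro group, so there is no direct precedent. The nearest guides are changes to the group on the nitrogen. Adding carboxy(phenyl)methyl there gave a modest step, a 5.0-fold higher number from compound 1 to compound 3 (0.70 log units; beyond the scatter), whereas adding 2-(methoxycarbonyl)ethyl gave a large one, a 380-fold higher number from compound 1 to compound 2 (2.57 log units; beyond the scatter). Both replaced hydrogen with a whole group, while the new change swaps hydrogen for a single atom at the far end of that group. A much smaller step is therefore expected in this assay, with neither direction favoured: the expected step is no change at the digits printed from compound 3 to compound 4 (within the scatter), within the scatter. For compound 4 the estimated value is 20 nM, with an expected range of 7 nM to 60 nM.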

Compound 4, half-maximal inhibitory concentration: 150 nM
Estimate against measurement, compound 4: 7.5-fold (0.88 log units) below; the whole stated range lies below it.
By their numbers in this assay, from the lowest: compound 1; then compound 3; then compound 4; then compound 2.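

In this assay, the far end of the carboxy(phenyl)methyl group proves sensitive to a very small change: a single fluoro atom on that aromatic carbon gives a 7.5-fold higher number from compound 3 to compound 4 (0.88 log units; beyond the scatter). This one atom moves the number beyond the scatter, so the ring is not a neutral passenger on the nitrogen. With fluoro in place, the substituted nitrogen sits further from the free amine, a 38-fold higher number from compound 1 to compound 4 (1.57 log units; beyond the scatter), and closer to the 2-(methoxycarbonyl)ethyl compound, a 10-fold lower number from compound 2 to compound 4 (1.00 log units; beyond the scatter); no available measurement bears on what lies behind this rise.

On these data alone, it remains open whether the rise belongs to fluoro itself or would follow any group on this carbon, such as chloro or an amine. Also open, as far as these compounds go, is how a primary amide in place of the carboxy group would behave alongside either ring.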